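Working notes: from compound 2 to compound 3

This account rests on a few compounds, and the source may have more. Where it says the series, first, only, none or still open, it means among the compounds named here.

In a functional assay on KB cells (Homo sapiens) for antiproliferative activity, read by sulforhodamine B assay, with a stated time of 3 days (on this read-out higher numbers stand for an effect only at larger amounts of compound and lower numbers for an effect already at smaller amounts), compound 1 `CCC1=C(O)c2c(oc(-c3ccc(O)cc3)cc2=O)C(CC)(CC)C1=O` gives 20.6 uM as a measured number. Compound 2 `CCC1=C(O)c2c(oc(-c3ccc(COC)cc3)cc2=O)C(CC)(CC)C1=O` gives > 52.4 uM as a limit of the assay and not a number. Going by the values given here, the one measured step is an at least 2.5-fold higher number from compound 1 to compound 2 (0.40 log units; beyond the scatter) and it ends at the limit of > 52.4 uM in this assay, at which 1 of the 2 values shown sits, so its true size stays open. Compound 3 `CCC1=C(O)c2c(oc(-c3cccc(C)c3)cc2=O)C(CC)(CC)C1=O` has 3-methylphenyl in place of 4-(methoxymethyl)phenyl on an aromatic carbon and so loses the methoxymethyl group of that step. Among the compounds with values here, with compound 1 at 20.6 uM as the only number, a modest step to a lower number is expected in this assay. For compound 3 another limit remains possible. For compound 3 the estimated value is 30 uM within an expected range of 10 uM to 70 uM in this estimate. The expected change is an at least 1.7-fold lower number from compound 2 to compound 3 (0.24 log units; that floor lies within the scatter) on this estimate.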

Compound 3, concentration for half-maximal effect: 49.7 uM
Compound 3: middle estimate off by 1.7-fold (0.22 log units), on the low side; measured number inside the range.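

In this assay, the change from 4-hydroxyphenyl to 3-methylphenyl gives a 2.4-fold higher number from compound 1 to compound 3 (0.38 log units; beyond the scatter), so a group without the hydroxy now has a measured number and not only a limit. Exchanging 4-(methoxymethyl)phenyl for 3-methylphenyl gives an at least 1.0-fold lower number from compound 2 to compound 3 (0.02 log units; that floor lies within the scatter), which shows no separation between these two groups. Compound 2 remains a limit, and the true size of this step stays open: the limit of > 52.4 uM in this assay, at which 1 of the 3 values shown sits.

Still open, on these data alone, is whether the hydroxy group itself or its place on the phenyl ring sets compound 1 apart. Also open, as far as these compounds go, is what an amine or a carboxylic acid on that ring would give.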